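Shortening the Side Chain on a Cyclic Phosphate Nucleoside

The source may hold more compounds than are shown below. What is called first, only, known or untested is meant among the compounds shown, and "the series" means these compounds.

Compound 1 `CCCCCCCCc1cn([C@H]2C[C@H](O)[C@@H](CO)O2)c(=O)[nH]c1=O` carries an octyl chain, and in a functional assay on L1210 cells (Mus musculus) (on this read-out lower numbers stand for stronger inhibition and higher numbers for weaker inhibition), compound 1 gives 72 ug/mL. Compound 3 `CCCCc1cn([C@H]2C[C@H](O)[C@@H](CO)O2)c(=O)[nH]c1=O` carries a butyl chain in its place; in this assay compound 3 reaches only a limit, > 500 ug/mL. Going by the values given here, the single measured step, an at least 6.9-fold higher number from compound 1 to compound 3 (0.84 log units; beyond the scatter), points to weaker inhibition as the chain grows shorter. Compound 2 `CCCCCCc1cn([C@H]2C[C@@H]3OP(=O)(O)OC[C@H]3O2)c(=O)[nH]c1=O` has a hexyl chain on a core closed into a cyclic phosphate; in this assay compound 2 reaches only a limit, > 500 ug/mL. Compound 2 therefore already stands at the limit of > 500 ug/mL in this assay, at which 2 of the 3 values shown sit. Compound 4 `CCCCc1cn([C@H]2C[C@@H]3OP(=O)(O)OC[C@H]3O2)c(=O)[nH]c1=O` differs from compound 2 by hydrogen in place of ethyl on a saturated chain carbon, four bonds along the chain from an aromatic carbon. This change runs in the same direction as the step from compound 1 to compound 3, which raised the number beyond the scatter. A further rise from a limit cannot show as a number, so compound 4 is expected to reach a limit again, with an estimated value of 1000 ug/mL, between 500 ug/mL and 5000 ug/mL. That estimate amounts to an expected step that the limit leaves unreadable from compound 2 to compound 4.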

Compound 4, concentration for 50% inhibition: 33.5 ug/mL
Beside the measured number, compound 4's estimate is 30-fold (1.47 log units) above it, and the stated range ends above it.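

On the core of compound 2, removing ethyl from the chain at this position strengthens inhibition in this assay: the result is an at least 14-fold lower number from compound 2 to compound 4 (1.17 log units; beyond the scatter), beyond the scatter, and its true size could be larger. The reading for compound 2 is only a limit: the limit of > 500 ug/mL in this assay, at which 2 of the 4 values shown sit. The earlier step on the core of compound 1, an at least 6.9-fold higher number from compound 1 to compound 3 (0.84 log units; beyond the scatter), ran the other way, so a shorter chain does not mean weaker inhibition across these compounds, and compound 3 and compound 4 go against any such rule on their different cores.

Going by these compounds, what remains open is how a propyl or an octyl chain would read on the core of compound 2, so the shape of the trend with chain length is unknown. Also open, on these data alone, is whether a chain ending in an amine or a carboxylic acid would keep this inhibition.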